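The source may report more compounds than this note shows. Statements on the series, on what has been measured and on what is new or still open speak of the compounds shown alone.

Compound 2 `COC[C@H]1CN(c2ccc(-n3cc(-c4ccccn4)cn3)c(F)c2)C(=O)O1` in an ADME assay on L02 cells (Homo sapiens) for cytotoxicity, read by MTT assay, with a stated time of 48 h (on this read-out lower numbers stand for stronger inhibition and higher numbers for weaker inhibition), gives > 400 ug/mL, which is a limit of the assay and not a number. Compound 1 `CCN1CCN(C[C@H]2CN(c3ccc(-n4cc(-c5ccccn5)cn4)c(F)c3)C(=O)O2)CC1` gives 99 ug/mL in this assay. The step of an at least 4.0-fold higher number from compound 1 to compound 2 (0.60 log units; beyond the scatter) thus ends at the limit of > 400 ug/mL in this assay, at which 1 of the 2 values shown sits. Compound 3 `COC(=O)NC[C@H]1CN(c2ccc(-n3cc(-c4ccccn4)cn3)c(F)c2)C(=O)O1` differs from compound 2 by (methoxycarbonyl)amino in place of methoxy on a saturated chain carbon bound to a saturated ring carbon. No measured step covers this exchange; the single step shown runs toward the limit, not away from it. The step of a number no higher from compound 2 to compound 3 (the limit leaves the size open) is therefore expected to stay within the scatter. Compound 3 is estimated at 400 ug/mL, with a range from 150 ug/mL to 1000 ug/mL.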

Compound 3, half-maximal inhibitory concentration: 71 ug/mL
Compound 3: the middle estimate sits 5.6-fold (0.75 log units) above what was measured; measured number outside the range, below it.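

In this assay, (methoxycarbonyl)amino in place of methoxy on this saturated chain carbon gives an at least 5.6-fold lower number from compound 2 to compound 3 (0.75 log units; beyond the scatter). In place of 4-ethylpiperazin-1-yl the same group gives a 1.4-fold lower number from compound 1 to compound 3 (0.14 log units; within the scatter), so a group without a ring falls in the same range as the ring-bearing one at this place. Compound 2 remains at a limit of the assay, not a number: the limit of > 400 ug/mL in this assay, at which 1 of the 3 values shown sits.

As far as these compounds go, whether the lower number goes with the hydrogen-bond donor of (methoxycarbonyl)amino or with the longer group stays open, since the two change together here. A plain amine or a hydroxy group at this place would help separate them.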